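Oxazolone propanoic acids: oxygen-linked substituent change

This account rests on a few compounds, and the source may have more. Where it says the series, first, only, none or still open, it means among the compounds named here.

Three compounds of the shared core have numbers in an assay on HEK293 cells for inhibition of kynurenine 3-monooxygenase (Homo sapiens), read by LC-MS, with a stated time of 20 h; a higher number here means a weaker inhibitor, a lower number a stronger inhibitor. Compound 1 `CC(C)Cc1cc2oc(=O)n(CCC(=O)O)c2cc1Cl` gives 794 nM in this assay. Compound 2 `CCc1cc2oc(=O)n(CCC(=O)O)c2cc1Cl` gives 316 nM, and the step of a 2.5-fold lower number from compound 1 to compound 2 (0.40 log units; beyond the scatter) is modest. Compound 3 `O=C(O)CCn1c(=O)oc2cc(OCC3CC3)c(Cl)cc21` gives 1580 nM, the highest of the three numbers; the step of a 2.0-fold higher number from compound 1 to compound 3 (0.30 log units; within the scatter) stays within the scatter, whereas the step of a 5.0-fold higher number from compound 2 to compound 3 (0.70 log units; beyond the scatter) is modest and beyond it.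

Compound 4 `C[C@@H](Oc1cc2oc(=O)n(CCC(=O)O)c2cc1Cl)c1ncco1` differs from compound 3 only in the substituent carried on the oxygen: a group of 7 heavy atoms (5 carbon, 1 nitrogen, 1 oxygen; one five-membered aromatic ring with 2 hetero atoms) in place of a group of 4 heavy atoms (4 carbon; one three-membered non-aromatic ring of carbon only), on an oxygen on an aromatic ring. Among the compounds with values here, the two measured steps into compound 3 both exchange a carbon substituent for cyclopropylmethoxy; no measured pair exchanges the group on that oxygen itself, so nothing in hand bears directly on this change, and its direction cannot be read from the series. The expectation is therefore a step near zero in this assay, with wide uncertainty, as a 1.1-fold lower number from compound 3 to compound 4 (0.02 log units; within the scatter). Compound 4 is estimated at 1500 nM, within a range from 400 nM to 6000 nM.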

Compound 4, half-maximal inhibitory concentration: 7940 nM
Compound 4: middle estimate off by 5.3-fold (0.72 log units), on the low side; the measured number lies above the stated range.
By their numbers in this assay, from the lowest: compound 2; then compounds 1 and 3 (each within the scatter of the next); then compound 4.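

In this assay, within the data shown here, the group carried on the oxygen is not neutral: the first measured exchange at this place gives a 5.0-fold higher number from compound 3 to compound 4 (0.70 log units; beyond the scatter) and so shows that the number responds to this substituent. Measured against the carbon-linked substituents, the gaps are greater, with a 10-fold higher number from compound 1 to compound 4 (1.00 log units; beyond the scatter) and a 25-fold higher number from compound 2 to compound 4 (1.40 log units; beyond the scatter), which makes compound 4 the weakest inhibitor of the four, with all three steps beyond the scatter. No available data bear on why the number rises with this change.

Going by these compounds, the entering group brings both the five-membered aromatic ring and a defined stereocentre, so the share of each in the step remains open. On these data alone, how a methyl, a phenyl ring or a chain ending in an amine on that oxygen would read in this assay is also open.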